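Dimethylamino for amino at the aromatic position of compound 3

The source may report more compounds than this note shows. Statements on the series, on what has been measured and on what is new or still open speak of the compounds shown alone.

Measured compounds:
compound 1 `CCCC[C@]1(CC)CS(=O)(=O)c2cc(O)ccc2[C@@H](c2ccccc2)[C@H]1O`: 90 nM
compound 2 `C=CCCCCCCCCOc1ccc2c(c1)S(=O)(=O)C[C@@](CC)(CCCC)[C@H](O)[C@@H]2c1ccccc1`: 16000 nM
compound 3 `CCCC[C@]1(CC)CS(=O)(=O)c2ccc(N)cc2[C@@H](c2ccccc2)[C@H]1O`: 68 nM

In an assay on cells for inhibition of ileal sodium/bile acid cotransporter (Homo sapiens) (on this read-out lower numbers stand for stronger inhibition and higher numbers for weaker inhibition), compound 3 gives 68 nM, the lowest of the three numbers. Compound 1 gives 90 nM, a value within the scatter of compound 3, so the two cannot be ordered. Among the compounds with values here, compound 2 gives 16000 nM, and the only measured step, a 180-fold higher number from compound 1 to compound 2 (2.25 log units; beyond the scatter), shows that a long chain placed on the oxygen of compound 1 is tolerated poorly.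

Compound 4 `CCCC[C@]1(CC)CS(=O)(=O)c2ccc(N(C)C)cc2[C@@H](c2ccccc2)[C@H]1O` differs from compound 3 in one place: dimethylamino in place of amino on an aromatic carbon. Within the data shown here, no measured step covers this change directly. The step from compound 1 to compound 2 concerns a different group and a much larger addition, so it bears only loosely here; the values of compound 1 and compound 3 show that small polar groups at this position give similar numbers. The expectation is therefore a small step, a 1.8-fold higher number from compound 3 to compound 4 (0.25 log units; within the scatter), within or near the scatter. Compound 4 is estimated at 120 nM, with a range from 40 nM to 400 nM.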

Compound 4, half-maximal inhibitory concentration: 5 nM
Estimate against measurement, compound 4: 24-fold (1.38 log units) above; the whole stated range lies above it.
By their numbers in this assay, from the lowest: compound 4; then compounds 3 and 1 (each within the scatter of the next); then compound 2.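

In this assay, dimethylamino in place of amino on this aromatic carbon gives a 14-fold lower number from compound 3 to compound 4 (1.13 log units; beyond the scatter) and so shows that this position responds strongly to a small change in its substituent. The earlier step showed only a large loss when dec-9-en-1-yl was placed on the oxygen of compound 1, whereas here a group growing from 1 heavy atom to 3 heavy atoms and losing its hydrogen-bond donor goes with stronger inhibition. No measurement shown here accounts for this gain.

The compounds shown leave open whether methylamino would give part of this gain, and whether diethylamino or a pyrrolidine ring would extend it or lose it. They also leave open how dimethylamino would behave in place of the hydroxyl of compound 1.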